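Replacing the phenylsulfonyl of compound 1 at the amine nitrogen

The compounds below may be only part of what the source reports. "The series", "measured", "known", "first", "only" and "open" are said of these compounds alone.

Compound 1 `O=S(=O)(NCC1CCN(CCCc2c[nH]c3ccc(-n4cnnc4)cc23)CC1)c1ccccc1` gives 60 nM in an assay on CHO cells for displacement of a labelled ligand from 5-hydroxytryptamine receptor 1B (Homo sapiens) (on this read-out higher numbers stand for weaker inhibition and lower numbers for stronger inhibition), the lowest of the two numbers recorded. Compound 2 `CN(Cc1cccs1)C1CCN(CCCc2c[nH]c3ccc(-n4cnnc4)cc23)CC1` gives 140 nM in this assay, and the step of a 2.3-fold higher number from compound 1 to compound 2 (0.37 log units; beyond the scatter) is modest. Compound 3 `CC(=O)Nc1ccc([C@H](C)NCC2CCN(CCCc3c[nH]c4ccc(-n5cnnc5)cc34)CC2)cc1` carries 1-(4-acetamidophenyl)ethyl in place of phenylsulfonyl on an amine nitrogen. Going by the values given here, the only step that bears on it is the one from compound 1 to compound 2, which also reworked the group on that side of the saturated ring and gave a modest weakening. For compound 3 a modest weakening is therefore expected, a 2.0-fold higher number from compound 1 to compound 3 (0.30 log units; within the scatter). Compound 3 is estimated at 120 nM, with a range from 40 nM to 400 nM.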

Compound 3, half-maximal inhibitory concentration: 9.3 nM
Beside the measured number, compound 3's estimate is 13-fold (1.11 log units) above it; measured number below the stated range.
By their numbers in this assay, from the lowest: compound 3; then compound 1; then compound 2.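

At the amine nitrogen, the phenylsulfonyl of compound 1 is not required in this assay: 1-(4-acetamidophenyl)ethyl in its place strengthens inhibition (a 6.5-fold lower number from compound 1 to compound 3 (0.81 log units; beyond the scatter)). Going by these compounds alone, the only earlier step moved the other way, so this is the first sign that a change on this side can lower the number. Nothing available accounts for the gain. The compounds shown do not separate the contributions of the acetamido group, the stereocentre and the loss of the sulfonyl. A plain benzyl or 1-phenylethyl group on the same nitrogen, or the opposite stereoisomer, would bear on this.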